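Swapping methyl for fluoro on compound 1

The source may hold more compounds than are shown below. What is called first, only, known or untested is meant among the compounds shown, and "the series" means these compounds.

Compound 1 `COc1ccc(/C=C2/CN(C)/C(=N/c3ccc(C)cc3)S2)cc1`: 7600 nM
Compound 2 `COc1ccc(/C=C2\S/C(=N\c3ccc(C)c(Cl)c3)N(C)C2=O)cc1`: > 100000 nM, a limit of the assay

Both compounds were tested in a functional assay on MCF7 cells (Homo sapiens) for antiproliferative activity, read by MTT assay, with a stated time of 72 h; a higher number here means a weaker inhibitor, a lower number a stronger inhibitor. Within the data shown here, compound 1 holds the only true number here, 7600 nM. Compound 2 is reported only as a limit, > 100000 nM.

The next compound, compound 3 `COc1ccc(/C=C2/CN(C)/C(=N/c3ccc(F)cc3)S2)cc1`, keeps the core of compound 1 and changes one group: fluoro in place of methyl on an aromatic carbon. This puts fluoro in place of methyl on an aromatic carbon, para to a large group, so 4-methylphenyl becomes 4-fluorophenyl. Among the measured compounds shown here, no measured pair shows what a single change does in this assay. For so small an exchange, little movement is expected, probably none beyond the scatter, and neither direction is favoured. The estimate therefore rests on compound 1 at 7600 nM. The estimated step is a 1.1-fold higher number from compound 1 to compound 3 (0.02 log units; within the scatter). For compound 3 the expected value is 8000 nM, with an estimated range from 2500 nM to 30000 nM.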

Compound 3, half-maximal inhibitory concentration: 8000 nM
For compound 3 middle estimate and measured number coincide at the digits printed, and the stated range covers the measured number.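

Among these compounds, compounds 1 and 3 form the first pair here that differs in only one place, so they give the first direct reading of what a single exchange does in this assay. On the aromatic carbon para to a large group, fluoro in place of methyl gives a 1.1-fold higher number from compound 1 to compound 3 (0.02 log units; within the scatter) and so the 4-methylphenyl and 4-fluorophenyl compounds cannot be told apart in this test. Nothing measured among the compounds shown speaks to why this exchange came out as it did.

On these data alone, this single exchange says little about how much else the position would accept, so the effect of an amine, a carboxylic acid or a longer chain such as butyl in the same place remains open. As far as these compounds go, whether fluoro and methyl would also match on a different core remains open too.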